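Dropping the biaryl arm: a bromo for 3-ethoxyphenyl

The source may report more compounds than this note shows. Statements on the series, on what has been measured and on what is new or still open speak of the compounds shown alone.

Measured so far, in an assay on isolated protein with Bile acid receptor (Homo sapiens) as the target; a higher number here means that more compound is needed for the effect, a lower number that less compound is needed:
Compound 1, `CCOc1cccc(-c2ccc(CN(C(=O)C3CCCCC3)c3cccc(/C=C/C(=O)OC)c3)cc2)c1`: 147 nM
Compound 2, `CCOc1cccc(-c2ccc(CN(C(=O)C(C)C)c3cccc(/C=C/C(=O)OC)c3)cc2)c1`: 173 nM
Compound 3, `CCOC/C=C/c1cccc(N(Cc2ccc(/C=C/C(=O)OC(C)(C)C)cc2)C(=O)C2CCCCC2)c1`: 220 nM

Compound 1 stands among three numbers that all sit within the usual scatter of one another; the step of a 1.2-fold higher number from compound 1 to compound 2 (0.07 log units; within the scatter) is within the scatter, and compound 3 differs from compound 1 in several places at once, so its value is only a point of comparison. The new compound 4, `COC(=O)/C=C/c1cccc(N(Cc2ccc(Br)cc2)C(=O)C2CCCCC2)c1`, differs from compound 1 by bromo in place of 3-ethoxyphenyl on an aromatic carbon. For the measured compounds named here, none of the measured steps bears on this change: the one step available concerns a group on a carbonyl carbon, not the part of compound 1 that is removed here. With a whole 3-ethoxyphenyl leaving and only a single bromine entering, compound 4 is expected to need more compound than compound 1, so the expected step is a 10-fold higher number from compound 1 to compound 4 (1.01 log units; beyond the scatter). The estimate for compound 4 in this assay is 1500 nM, within a range from 400 nM to 6000 nM.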

Compound 4, half-maximal effective concentration: > 1000 nM
Compound 4 ended at the assay's limit; the forecaster's own chance of this, stated with the estimate: 15%; the middle value is on the limit's open side.
By their numbers in this assay, from the lowest: compounds 1, 2 and 3 (each within the scatter of the next). At a limit, above all of these: compound 4.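

In this assay, for the compounds shown here, the only earlier step between two compounds that differ in one place, a 1.2-fold higher number from compound 1 to compound 2 (0.07 log units; within the scatter), concerned a group on a carbonyl carbon and showed no change that could be told from noise. Going by these compounds alone, putting bromo in place of 3-ethoxyphenyl on an aromatic carbon gives the first step beyond the scatter, an at least 6.8-fold higher number from compound 1 to compound 4 (0.83 log units; beyond the scatter), so in this pair the group at this position does affect the number. The reading for compound 4 is a limit of the assay and not a number, which leaves the full size of the step unknown: the limit of > 1000 nM in this assay, at which 1 of the 4 values shown sits.

Going by these compounds, it remains open whether the ring of the 3-ethoxyphenyl or its ethoxy matters more, a question that a plain phenyl in this place would help to settle. On these data alone, how an amine or a carboxylic acid on that ring would behave is also open.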